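A longer chain on sulfur in a small shared core

The compounds below may be only part of what the source reports. "The series", "measured", "known", "first", "only" and "open" are said of these compounds alone.

Three compounds share a core in which a sulfur carries a short chain, and all three were tested in a functional assay on SMMC-7721 cells (Homo sapiens) for cytotoxicity, read by MTT assay, with a stated time of 72 h; on this read-out higher numbers stand for weaker inhibition and lower numbers for stronger inhibition. Compound 1 `COc1ccc(NC(=O)CSC(=S)N[C@H]2CCOC2=O)cc1` carries an anilide bearing a methoxy group. In this assay compound 1 reaches only the limit of the assay, > 128000 nM. Compound 2 `O=C(CSC(=S)N[C@H]1CCOC1=O)Nc1cccc([N+](=O)[O-])c1` carries an anilide bearing a nitro group. Compound 2 likewise gives only the limit, > 128000 nM. Compound 3 `CSC(=S)N[C@H]1CCOC1=O` is the smallest of the three, with a methyl group on the sulfur and no anilide. Compound 3 also stops at the limit, > 128000 nM. Compound 3 therefore stands together with the other two at the same boundary: every value shown is a limit and none is a number, as summarised by the limit of > 128000 nM in this assay, at which 3 of the 3 values shown sit.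

Compound 4 `CCCCCCSC(=S)N[C@H]1CCOC1=O` is not yet measured. It differs from compound 3 by pentyl in place of hydrogen on a saturated chain carbon bound to a sulfur. Going by the values given here, no measured pair in this set differs in one place only, so no measured step guides the expectation. With every shown value resting at the limit, the expectation is that the step that the limit leaves unreadable from compound 3 to compound 4 brings no change beyond the scatter, and compound 4 is estimated at 150000 nM, within a range from 40000 nM to 500000 nM.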

Compound 4, half-maximal inhibitory concentration: > 128000 nM
Compound 4 ended at the assay's limit; the forecaster's own chance of this, stated with the estimate: 75%; the middle value lies beyond the limit too.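

No size can be read for the change from compound 3 to compound 4, since each of these compounds gives only a limit and not a number: the limit of > 128000 nM in this assay, at which 4 of the 4 values shown sit.

The compounds shown leave open whether any compound with this shared core gives a real number in this assay, and so how changing the chain on sulfur affects the result.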